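A few compounds are considered here, and "the series" means these few. Any claim that something is new, unique, unknown or untested is made for them only; others in the source may bear on it.

Working notes on the series. The shared core of compound 1 `COc1cc2nc(C)cc(OCC(=O)Nc3cc(C)cc(C)c3)c2cc1OC` carries an amide-linked aryl group; in a toxicity assay on HepG2 cells (Homo sapiens) for inhibition, read by CellTiter-Glo, with a stated time of 48 h (a higher number here means a weaker inhibitor, a lower number a stronger inhibitor), compound 1 gives 10000 nM. Compound 2 `CCCc1cc(OCC(=O)Nc2cc(C)cc(C)c2)c2cc(OC)ccc2n1` keeps that arrangement on a differently substituted core, and in this assay compound 2 gives 12600 nM. Compound 3 `COc1ccc2nc(C)cc(OCC(=O)NCc3cc(C)cc(C)c3)c2c1`, with the 3,5-dimethylbenzyl group on the amide nitrogen, returns only a limit in this assay: compound 3 gives > 100000 nM, which is the edge of the measurement and not a number. Of the three values shown, one sits at that limit (the limit of > 100000 nM in this assay, at which 1 of the 3 values shown sits), so compound 3 stands apart from compound 1 and compound 2 only as an undetermined value beyond the range in which they were read.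

Compound 4 `COc1ccc2nc(C)cc(OCC(=O)Nc3cc(C)nc(C)n3)c2c1` follows from compound 3 by the change (2,6-dimethylpyrimidin-4-yl in place of 3,5-dimethylbenzyl on an amide-type nitrogen). The aryl group therefore sits on the amide nitrogen directly, as in compound 1 and compound 2, rather than through the benzyl carbon of compound 3. Going by the values given here, no step between measured compounds covers this change. In this assay a move toward lower numbers, back toward the region of compound 1 and compound 2, is expected, though its size cannot be anchored since compound 3 has no number. The estimated step from compound 3 to compound 4 is an at least 3.3-fold lower number from compound 3 to compound 4 (0.52 log units; beyond the scatter). Compound 4 is expected to give about 30000 nM, within 8000 nM to 100000 nM.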

Compound 4, half-maximal inhibitory concentration: > 100000 nM
Compound 4 was reported as a limit; the forecaster's own chance of this, stated with the estimate: 40%; middle value at least 3.3-fold (0.52 log units) away from the limit.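

In this assay compound 4 gives > 100000 nM, which is a limit and not a number. Compound 3 stands at the same limit, so no step between compound 3 and compound 4 can be read: the limit of > 100000 nM in this assay, at which 2 of the 4 values shown sit.

The compounds shown leave open whether compound 3 and compound 4 differ at all in this assay, and by how much.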